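A Morpholin-4-yl Swap at the Thiocarbonyl Carbon

This account rests on a few compounds, and the source may have more. Where it says the series, first, only, none or still open, it means among the compounds named here.

Compound 1 `Cc1ccnc(/C(N)=N/NC(=S)N2CCCC2)c1` — 86.4%
Compound 2 `N/C(=N\NC(=S)N1CCN(c2ccccn2)CC1)c1ccc(F)cn1` — 87%

In a functional assay on HeLa cells (Homo sapiens) for cytotoxicity, read by MTT assay, with a stated time of 72 h, tested at 30 uM (on this read-out higher numbers stand for more inhibition of growth at the one concentration tested and lower numbers for less inhibition of growth), compound 1 gives 86.4%. Compound 2 gives 87% in this assay, and the two numbers lie within the scatter of each other, so compound 1 stands alongside compound 2 with no difference to report. Compound 3 `Cc1ccnc(/C(N)=N/NC(=S)N2CCOCC2)c1` differs from compound 1 by morpholin-4-yl in place of pyrrolidin-1-yl on a thiocarbonyl carbon. Within the data shown here, no step between measured compounds exists to guide the size of this change, and both measured numbers sit high. Compound 3 is therefore expected to show a number 6.4 percentage points lower from compound 1 to compound 3 (within the scatter), a step not beyond the scatter. Compound 3 is estimated at 80%, with a range from 60% to 95%.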

Compound 3, percent growth inhibition at one concentration: 45.2%
The estimate for compound 3 lay 34.8 percentage points above the measured number; the measured number lies below the stated range.
By their numbers in this assay, from the lowest: compound 3; then compounds 1 and 2 (each within the scatter of the next).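

Morpholin-4-yl in place of pyrrolidin-1-yl on a thiocarbonyl carbon gives a number 41.2 percentage points lower from compound 1 to compound 3 (beyond the scatter) in this assay, the first single change shown at this position, and it shows that the group held there can matter greatly. The step changes both the ring size and the oxygen of morpholin-4-yl together, and this one pair cannot separate the two. Nothing measured here explains the drop. Piperidin-1-yl, a six-membered ring without the oxygen, would separate them, and whether its value would stay near that of compound 1 or that of compound 3 remains open.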